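A few compounds are considered here, and "the series" means these few. Any claim that something is new, unique, unknown or untested is made for them only; others in the source may bear on it.

Measured compounds:
- compound 1 `C[C@@H]1CCN(c2cc(-c3ccccc3)nc3ncnn23)C[C@@H]1N(C)c1ncnc2[nH]ccc12`: 84900 nM
- compound 2 `Cc1cc(N2CC[C@@H](C)[C@@H](N(C)c3ncnc4[nH]ccc34)C2)n2nc(SCCc3ccccc3)nc2n1`: 6190 nM
- compound 3 `CCCCCc1c(C)nc2nc(SCc3ccc(Cl)cc3)nn2c1N1CC[C@@H](C)[C@@H](N(C)c2ncnc3[nH]ccc23)C1`: > 100000 nM

All three were tested in a functional assay on MGC-803 cells (Homo sapiens) for inhibition, read by MTT assay, with a stated time of 72 h; on this read-out higher numbers stand for weaker inhibition and lower numbers for stronger inhibition. Among the numbers that are actual numbers, compound 2 stands lowest, with 6190 nM, and compound 1 gives the weaker result of 84900 nM, a gap beyond the usual scatter. For compound 3 the assay reports only a limit, > 100000 nM, so no number is known for it; this is the limit of > 100000 nM in this assay, at which 1 of the 3 values shown sits.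

The unmeasured compound 4 `Cc1cc(N2CC[C@@H](C)[C@@H](N(C)c3ncnc4[nH]ccc34)C2)n2nc(SCCCc3ccccc3)nc2n1` keeps the whole framework of compound 2 and changes only the side chain on the sulfur: benzyl in place of phenyl on a saturated chain carbon, two bonds along the chain from a sulfur. Put another way, phenethylsulfanyl becomes (3-phenylpropyl)sulfanyl, the chain growing by one saturated carbon. Going by the values given here, no measured pair in this set shows what such a lengthening does. With no such guide, the expected step of a 1.1-fold higher number from compound 2 to compound 4 (0.05 log units; within the scatter) is small, in no particular direction, and not beyond the scatter. Compound 4 is therefore estimated at 7000 nM, within a range from 2500 nM to 20000 nM.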

Compound 4, half-maximal inhibitory concentration: > 100000 nM
Compound 4: no number, only a limit (the forecaster's own chance of this, stated with the estimate: 5%); middle value at least 14-fold (1.15 log units) from the limit.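

In this assay, the move from phenethylsulfanyl to (3-phenylpropyl)sulfanyl gives an at least 16-fold higher number from compound 2 to compound 4 (1.20 log units; beyond the scatter) with only one saturated carbon added to the chain. The earlier compounds shown here gave no view of this side chain alone, and this pair shows that its length matters greatly here, since the measurable inhibition of compound 2 is not retained on lengthening. The value of compound 4 is a limit, not a number, so the real size of the step stays unknown: the limit of > 100000 nM in this assay, at which 2 of the 4 values shown sit.

The compounds shown leave open whether a shorter chain, such as benzylsulfanyl or methylsulfanyl, would give stronger or weaker inhibition than phenethylsulfanyl. They also leave open whether an amine or a carboxylic acid in place of the phenyl at the chain end would keep any inhibition.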